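A few compounds are considered here, and "the series" means these few. Any claim that something is new, unique, unknown or untested is made for them only; others in the source may bear on it.

Working notes on the series.

Compound 1 `COC(=O)c1ccc(OCCCCOc2ccc(C(=O)CC3CCCC3)c(O)c2C)cc1` has no result in an assay on HEK293 cells for positive allosteric modulation of metabotropic glutamate receptor 3 (Rattus norvegicus), read by thallium flux, with a stated time of 2.5 min; a lower number here means that less compound is needed, a higher number that more compound is needed for the effect; for compound 1 the entry reads "not determined" (no result reported). Compound 2 `Cc1c(OCCCCOCOc2ccc(C(=O)O)cc2)ccc(C(=O)CC2CCCC2)c1O` carries a (4-carboxyphenoxy)methyl group on the oxygen at the end of the chain, and in this assay compound 2 gives 1910 nM. Compound 3 `Cc1ccc(C(=O)O)cc1OCCCCOc1ccc(C(=O)CC2CCCC2)c(O)c1C` carries 5-carboxy-2-methylphenyl in that place instead. For compound 3 this assay reports only a limit, > 10000 nM, so compound 3 sits at the limit of > 10000 nM in this assay, at which 1 of the 3 values shown sits, and no single number is known for it. Within the data shown here, the change an at least 5.2-fold higher number from compound 2 to compound 3 (0.71 log units; beyond the scatter) is the only measured step in the set.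

Compound 4 `Cc1cc(OCCCCOc2ccc(C(=O)CC3CCCC3)c(O)c2C)ccc1C(=O)O` is not yet measured. It differs from compound 3 by 4-carboxy-3-methylphenyl in place of 5-carboxy-2-methylphenyl on an oxygen on a saturated carbon; the two compounds hold the same atoms joined differently. Among the measured compounds shown here, the only step that bears on this change is the one from compound 2 to compound 3, which moved the number up beyond the scatter, and it concerns a different pair of groups. Because compound 3 stands at the limit of > 10000 nM in this assay, at which 1 of the 3 values shown sits, the direction for compound 4 can only be downward or unchanged. The working expectation for compound 4 is a step of an at least 2.5-fold lower number from compound 3 to compound 4 (0.39 log units; beyond the scatter), carrying real uncertainty. Compound 4 is therefore estimated at 4000 nM, with a range from 1000 nM to 15000 nM.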

Compound 4, half-maximal effective concentration: > 10000 nM
Compound 4: only a limit was reported (the forecaster's own chance of this, stated with the estimate: 40%); middle value at least 2.5-fold (0.39 log units) away from the limit.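

Exchanging 5-carboxy-2-methylphenyl for 4-carboxy-3-methylphenyl on this oxygen does not yield a single number in this assay: for compound 4 the entry is only a limit, > 10000 nM. The step between compound 3 and compound 4 cannot be read, so nothing can be said about any difference between these two groups. Replacing (4-carboxyphenoxy)methyl with 4-carboxy-3-methylphenyl gives an at least 5.2-fold higher number from compound 2 to compound 4 (0.71 log units; beyond the scatter), which leaves compound 2 as the only compound here with a single number, while the limit now holds a second entry: the limit of > 10000 nM in this assay, at which 2 of the 4 values shown sit.

From the compounds shown here alone, the actual values of compound 3 and compound 4 remain open. Also open, going by these compounds, is how a 4-carboxyphenyl group without the methyl would read on this oxygen, and so whether the methyl or the different link to the ring matters for the gap from compound 2.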